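A Phenyl Swap With No Starting Number

The compounds below may be only part of what the source reports. "The series", "measured", "known", "first", "only" and "open" are said of these compounds alone.

Measured so far in a physicochemical assay for permeability, using PAMPA; on this read-out higher numbers stand for higher permeability and lower numbers for lower permeability:
- compound 1 `Cc1oc(-c2ccc(F)cc2)nc1CN1CCC(C(=O)NCCCN2C[C@H](C)C[C@H](C)C2)CC1`: "not determined" (no result reported)
- compound 2 `Cc1cccc(Cl)c1-c1nc(CN2CCC(C(=O)NCCCN3CCC(C(C)C)CC3)CC2)c(C)o1`: "not determined" (no result reported)
- compound 3 `Cc1ccccc1-c1nc(CN2CCC(C(=O)N3CCN(CCN(C)C)CC3)CC2)c(C)o1`: 14 10^-6 cm/s

The starting point of this step has no number to stand on. In this assay compound 1 is recorded as "not determined" (no result reported), so no result was reported for it. The same holds for compound 2, which is recorded as "not determined" (no result reported). Only compound 3 has a real reading, at 14 10^-6 cm/s.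

The next compound to be tested is compound 4 `Cc1cccc(-c2nc(CN3CCC(C(=O)NCCCN4C[C@H](C)C[C@H](C)C4)CC3)c(C)o2)c1`. It keeps the rest of compound 1 and changes one group: 3-methylphenyl stands in place of 4-fluorophenyl on an aromatic carbon of a five-membered aromatic ring with 1 nitrogen and 1 oxygen (3-methylphenyl in place of 4-fluorophenyl on an aromatic carbon). Each of the two groups is one six-membered aromatic ring of carbon only, and neither has a net charge.

Within the data shown here, no pair of measured compounds shows what a change like this does, so the size of the step cannot be read from the data. The expectation is a step no larger than the usual scatter of this assay, with no favoured direction. The only anchor for the level is compound 3 at 14 10^-6 cm/s, and one reading makes a weak anchor, so the range has to be wide. For compound 4 the expected value is 11 10^-6 cm/s, with an estimated range from 3 10^-6 cm/s to 30 10^-6 cm/s.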

Compound 4, apparent permeability: 279 10^-6 cm/s
Compound 4: middle estimate off by 25-fold (1.40 log units), on the low side, outside the stated range (above it).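

Among these compounds, with "not determined" recorded for compound 1 in this assay, no step from compound 1 to compound 4 can be read. As far as these compounds go, what replacing 4-fluorophenyl with 3-methylphenyl does to this read-out therefore stays open, as does whether the high reading of compound 4 belongs to that change or to the shared core. No available evidence bears on this result.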